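Methoxy in place of fluoro: compound 3 in the series

A few compounds are considered here, and "the series" means these few. Any claim that something is new, unique, unknown or untested is made for them only; others in the source may bear on it.

Measured so far:
compound 1, `CCN1CCN(c2cc(C)c3cc(NC(=O)c4ccccc4C)ccc3n2)CC1`, in a functional assay on SK-BR-3 cells (Homo sapiens) for antiproliferative activity, read by MTT assay, with a stated time of 72 h (a lower number here means a stronger inhibitor, a higher number a weaker inhibitor), gives 29200 nM
compound 2, `CCN1CCN(c2cc(C)c3cc(NC(=O)c4ccccc4F)ccc3n2)CC1`, in this assay gives 38100 nM

Both compounds share the same core and differ only in the group on the aromatic carbon of the amide aryl part. Among the measured compounds shown here, compound 2 cannot be separated from compound 1 on these numbers: the single step recorded, a 1.3-fold higher number from compound 1 to compound 2 (0.12 log units; within the scatter), lies within the scatter, so both sit at the same weak level in this assay.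

Compound 3, `CCN1CCN(c2cc(C)c3cc(NC(=O)c4ccccc4OC)ccc3n2)CC1`, continues at the same position with a different group: methoxy in place of fluoro on an aromatic carbon.

For the measured compounds named here, the only step that bears on it is the one from methyl to fluoro at this place, and it was small: a 1.3-fold higher number from compound 1 to compound 2 (0.12 log units; within the scatter). Going by the values given here, no measured step covers methoxy at this place, so the change from fluoro to methoxy has no direct precedent. Given that the one exchange at this place gave a step within the scatter, compound 3 is expected to remain within the scatter of compound 2, with a 1.2-fold lower number from compound 2 to compound 3 (0.08 log units; within the scatter).

Estimated value for compound 3 in this assay: 32000 nM, expected between 11000 nM and 95000 nM.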

Compound 3, half-maximal inhibitory concentration: 15700 nM
The estimate for compound 3 lay 2.0-fold (0.31 log units) above the measured number; the measured number falls inside the stated range.
By their numbers in this assay, from the lowest: compounds 3, 1 and 2 (each within the scatter of the next, the first and the last beyond it).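

In this assay the place ortho to a large group now yields its first step beyond the scatter, modest in size, with methoxy in place of fluoro (a 2.4-fold lower number from compound 2 to compound 3 (0.39 log units; beyond the scatter)), so the group at this place can shift the number, though only slightly so far. Methoxy in place of methyl does not separate in the same way (a 1.9-fold lower number from compound 1 to compound 3 (0.27 log units; within the scatter)), which leaves compound 1 within the scatter of both compound 2 and compound 3; the series therefore divides only at its two ends, and compound 3 at 15700 nM still sits at a high number. Nothing available on these compounds gives a reason for the step from fluoro to methoxy.

Three small groups at one place cannot show whether the step reflects the arrival of methoxy or the departure of fluoro, or whether it would hold on a changed core. Also open, as far as these compounds go, is how this place responds to an amine, a carboxylic acid or a longer chain such as ethoxy, any of which could show whether the number moves further than the modest step seen here.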